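N-methylation of an inactive pyrimidinone sulfonamide

The source may hold more compounds than are shown below. What is called first, only, known or untested is meant among the compounds shown, and "the series" means these compounds.

Compound 1 `Cc1ccc(S(=O)(=O)Nc2cc[nH]c(=O)n2)cc1` gives in a functional assay on SW-620 cells (Homo sapiens) for inhibition, read by MTT assay, with a stated time of 72 h (on this read-out lower numbers stand for stronger inhibition and higher numbers for weaker inhibition), only a limit, > 100000 nM. Compound 2 `O=c1nc(NO)cc[nH]1` also gives only a limit in this assay, > 100000 nM. Both readings sit at the limit of > 100000 nM in this assay, at which 2 of the 2 values shown sit, so compound 1 stands on no number at all, only on a limit. Compound 3 `Cc1ccc(S(=O)(=O)Nc2ccn(C)c(=O)n2)cc1` differs from compound 1 by methyl in place of hydrogen on an aromatic nitrogen. For the measured compounds named here, no measured step is available for this change. In this assay the expected step is a number no higher from compound 1 to compound 3 (the limit leaves the size open), none beyond the scatter. Compound 3 is therefore estimated at 100000 nM, ranging 30000 nM to 300000 nM, most likely reported once more as a limit.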

Compound 3, half-maximal inhibitory concentration: > 100000 nM
Compound 3: a limit, no number; the forecaster's own chance of this, stated with the estimate: 85%; the middle value lies on the limit itself.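

No step can be read from compound 1 to compound 3, since each stands only on a limit: the limit of > 100000 nM in this assay, at which 3 of the 3 values shown sit.

In this assay the compounds shown leave open whether methyl in place of hydrogen on an aromatic nitrogen changes inhibition at all.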